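This account rests on a few compounds, and the source may have more. Where it says the series, first, only, none or still open, it means among the compounds named here.

In a functional assay on MKN-45 cells (Homo sapiens) for cytotoxicity (on this read-out lower numbers stand for stronger inhibition and higher numbers for weaker inhibition), compound 1 `COc1ccc(S(=O)(=O)N2CCc3cccc(NC(=O)C(C)(C)C)c32)cc1` gives 289 nM and compound 2 `COc1ccc(S(=O)(=O)N2CCc3cccc(NS(=O)(=O)c4ccc(F)cc4)c32)cc1` gives 890 nM, a modest difference: a 3.1-fold higher number from compound 1 to compound 2 (0.49 log units; beyond the scatter). Compound 3 `COc1ccc(S(=O)(=O)N2CCc3cccc(NCc4ccccc4)c32)cc1` reads > 10000 nM, which is a limit of the assay and not a number. The next structure is compound 4 `COc1ccc(S(=O)(=O)N2CCc3cccc(N)c32)cc1`, with hydrogen in place of benzyl on a nitrogen on an aromatic ring. Going by the values given here, no measured compound carries hydrogen on that nitrogen, so the available guidance is indirect. Two large steps bear on the change, both with benzyl entering: an at least 34-fold higher number from compound 1 to compound 3 (1.53 log units; beyond the scatter) and an at least 11-fold higher number from compound 2 to compound 3 (1.05 log units; beyond the scatter). Removing benzyl is therefore expected to lower the number in this assay, by a moderate to large step, although hydrogen matches neither group it would be compared with. The expected change is an at least 5.0-fold lower number from compound 3 to compound 4 (0.69 log units; beyond the scatter). For compound 4, the estimated value is 2000 nM, with an expected range of 400 nM to 10000 nM.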

Compound 4, half-maximal inhibitory concentration: 1200 nM
For compound 4 the middle estimate is 1.7-fold (0.22 log units) above the measured one, within the range that was stated.
By their numbers in this assay, from the lowest: compound 1; then compounds 2 and 4 (each within the scatter of the next). At a limit, above all of these: compound 3.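

In this assay, hydrogen on this nitrogen gives a measurable value, with an at least 8.3-fold lower number from compound 3 to compound 4 (0.92 log units; beyond the scatter), so the loss in compound 3 goes with benzyl entering and not simply with the absence of a carbonyl or sulfonyl group. The reading for compound 3 is a limit and not a number: the limit of > 10000 nM in this assay, at which 1 of the 4 values shown sits. Hydrogen and (4-fluorophenyl)sulfonyl are not told apart, with a 1.3-fold higher number from compound 2 to compound 4 (0.13 log units; within the scatter), while (tert-butyl)carbonyl does separate from hydrogen, with a 4.2-fold higher number from compound 1 to compound 4 (0.62 log units; beyond the scatter).

As far as these compounds go, whether that separation belongs to the carbonyl or to the tert-butyl group stays open; an acetyl group on this nitrogen would bear on it. Also open, from the compounds shown here alone, is whether a small alkyl group such as methyl on the nitrogen reads like hydrogen or like benzyl.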